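A few compounds are considered here, and "the series" means these few. Any claim that something is new, unique, unknown or untested is made for them only; others in the source may bear on it.

Within the data shown here, compound 2 `CCCCc1cn(C[C@H](O)[C@H]2OC(=O)C(OCc3ccccc3)=C2OCc2ccccc2)nn1` gives 10400 nM in a functional assay on HCT-116 cells (Homo sapiens) for antiproliferative activity, read by MTT assay, with a stated time of 72 h (a lower number here means a stronger inhibitor, a higher number a weaker inhibitor), the lower of the two numbers so far; compound 1 `O=C1O[C@H]([C@@H](O)Cn2cc(-c3cccc(O)c3)nn2)C(OCc2ccccc2)=C1OCc1ccccc1` gives 42900 nM. Among the measured compounds shown here, the only measured step, a 4.1-fold lower number from compound 1 to compound 2 (0.62 log units; beyond the scatter), exchanged an aryl group for a chain on the same aromatic carbon. Compound 3 `CCCCCc1ccc(-c2cn(C[C@H](O)[C@H]3OC(=O)C(OCc4ccccc4)=C3OCc3ccccc3)nn2)cc1` carries 4-pentylphenyl in place of butyl on an aromatic carbon, an aryl group again, yet one that holds a pentyl chain and no hydroxyl, so the earlier step bears on it only loosely. A step near or within the scatter in this assay is expected, direction uncertain. The estimated step is a 1.5-fold lower number from compound 2 to compound 3 (0.17 log units; within the scatter). For compound 3 the expected value is 7000 nM, ranging from 2000 nM to 25000 nM.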

Compound 3, half-maximal inhibitory concentration: 13800 nM
For compound 3 the middle estimate is 2.0-fold (0.29 log units) below the measured one; the measured number falls inside the stated range.
By their numbers in this assay, from the lowest: compounds 2 and 3 (each within the scatter of the next); then compound 1.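

On the aromatic carbon of the five-membered aromatic ring, this assay does not separate butyl from 4-pentylphenyl: the result is a 1.3-fold higher number from compound 2 to compound 3 (0.12 log units; within the scatter), despite the added aromatic ring. The two aryl groups are separated, with a 3.1-fold lower number from compound 1 to compound 3 (0.49 log units; beyond the scatter), so an aryl group at this carbon does not by itself fix the number, and 3-hydroxyphenyl and 4-pentylphenyl give different results. No measurement on hand explains either step.

As far as these compounds go, it remains open how an unsubstituted phenyl would compare at this carbon. The effect of an amine or carboxylic acid on the phenyl ring, or of a chain longer than butyl, is also unresolved.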